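Trifluoromethyl position shift on the shared diaryl-pyridinol core

This account rests on a few compounds, and the source may have more. Where it says the series, first, only, none or still open, it means among the compounds named here.

Compound 1 `Oc1ccc(-c2cc(-c3cccc(C(F)(F)F)c3)cc(-c3ccccc3O)n2)cc1` — > 50000 nM
Compound 2 `Oc1ccc(-c2cc(-c3cccc(C(F)(F)F)c3)cc(-c3cccc(O)c3)n2)cc1` — 16200 nM
Compound 3 `Oc1ccc(-c2cc(-c3ccccc3C(F)(F)F)cc(-c3ccc(O)cc3)n2)cc1` — > 50000 nM

In a functional assay on HeLa cells (Homo sapiens) for inhibition (a higher number here means a weaker inhibitor, a lower number a stronger inhibitor), compound 1 reaches only the limit > 50000 nM. Compound 2 gives 16200 nM in this assay. For the measured compounds named here, the one measured step, an at least 3.0-fold lower number from compound 1 to compound 2 (0.48 log units; beyond the scatter), concerns the hydroxyphenyl group and not the trifluoromethylphenyl group. Going by the values given here, compound 3 also sits at a limit, > 50000 nM, so it can be placed only as no stronger than that boundary; that two of three values sit at the limit of > 50000 nM in this assay, at which 2 of the 3 values shown sit, means the series so far gives little to stand on.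

Compound 4 `Oc1ccc(-c2cc(-c3cccc(C(F)(F)F)c3)cc(-c3ccc(O)cc3)n2)cc1` is the next compound to be measured. It differs from compound 3 by 3-(trifluoromethyl)phenyl in place of 2-(trifluoromethyl)phenyl on an aromatic carbon. Among the compounds with values here, no measured pair differs only in this way, so no step bears on it directly; compound 2 is the one measured compound that carries the 3-(trifluoromethyl)phenyl group and also returns a number rather than a limit, while compound 1, which carries the same group, does not. On this thin basis compound 4 is expected to land near 30000 nM, within 8000 nM to 100000 nM, and the expected step of an at least 1.6-fold lower number from compound 3 to compound 4 (0.22 log units; that floor lies within the scatter) may still end at a limit.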

Compound 4, half-maximal inhibitory concentration: > 50000 nM
Compound 4 ended at the assay's limit; the forecaster's own chance of this, stated with the estimate: 50%; at least 1.6-fold (0.22 log units) between middle value and limit.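

In this assay the hydroxyphenyl group gives the one readable result: an at least 3.0-fold higher number from compound 2 to compound 4 (0.48 log units; beyond the scatter), with 4-hydroxyphenyl in place of 3-hydroxyphenyl. For the compounds shown here, with 3-(trifluoromethyl)phenyl held fixed, the three hydroxyphenyl placements can now be set side by side: compound 2, with 3-hydroxyphenyl, is the only one that returns a number, at 16200 nM. Compound 1, with 2-hydroxyphenyl, and compound 4, with 4-hydroxyphenyl, both stop at a limit of the assay. The change from 2-(trifluoromethyl)phenyl to 3-(trifluoromethyl)phenyl does not bring compound 4 off that limit, and the steps to compound 4 from compound 3 and from compound 1 cannot be read, as both ends of each are limits: the limit of > 50000 nM in this assay, at which 3 of the 4 values shown sit.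

Any real differences among compound 1, compound 3 and compound 4 remain hidden, and so does the effect of the trifluoromethyl position, which would need a pair that returns numbers, such as 2-(trifluoromethyl)phenyl combined with 3-hydroxyphenyl. Also open, as far as these compounds go, is whether the hydroxyl of the 3-hydroxyphenyl group in compound 2 can give way to an amine, a carboxylic acid or a methoxy group with a number still returned.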